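The source may hold more compounds than are shown below. What is called first, only, known or untested is meant among the compounds shown, and "the series" means these compounds.

Measured compounds:
- compound 1 `O=c1c(CSC(=S)N2CCN(c3ccccc3)CC2)coc2ccccc12` gives 7100 nM
- compound 2 `O=c1cc(CSC(=S)N2CCN(c3ccccc3)CC2)oc2cc(Cl)ccc12` gives 25900 nM

Both were tested in a functional assay on HeLa cells (Homo sapiens) for antiproliferative activity, read by MTT assay, with a stated time of 72 h; on this read-out higher numbers stand for weaker inhibition and lower numbers for stronger inhibition. On the two numbers shown, compound 1 stands at the lower one, and compound 2 at a number higher by a margin beyond the usual scatter. Within the data shown here, the two compounds differ in more than one place, so no single step between them can be drawn, and their gap says only that compound 1 is the stronger inhibitor of the pair.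

Compound 3 `CN1CCN(C(=S)SCc2coc3ccccc3c2=O)CC1` has not yet been measured. It differs from compound 1 by methyl in place of phenyl on an amine nitrogen in a ring. Among the measured compounds shown here, no measured pair shows this change, so its effect cannot be read from these data. The expectation is a modest weakening, with the step of a 1.7-fold higher number from compound 1 to compound 3 (0.23 log units; within the scatter) estimated as small to moderate and possibly within the scatter. For compound 3 the estimate in this assay is 12000 nM, with a range from 4000 nM to 40000 nM.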

Compound 3, half-maximal inhibitory concentration: 5900 nM
Beside the measured number, compound 3's estimate is 2.0-fold (0.31 log units) above it; low and high end bracket the measured number.
By their numbers in this assay, from the lowest: compounds 3 and 1 (each within the scatter of the next); then compound 2.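

In this assay, among these compounds, the exchange of phenyl for methyl on the amine nitrogen in the ring gives a 1.2-fold lower number from compound 1 to compound 3 (0.08 log units; within the scatter) and so provides the first comparison in this set that differs in a single place. It shows that, at this position, a methyl of 1 heavy atom and no ring reads the same within the scatter as a phenyl of 6 heavy atoms and one aromatic ring, so the phenyl of compound 1 is not required for the activity seen on these cells. No measured evidence on these compounds accounts for this lack of separation.

As far as these compounds go, it remains open whether other groups on this nitrogen, such as a benzyl, an acetyl, a longer alkyl chain or a chain ending in a carboxylic acid, would separate from compound 1 and compound 3 beyond the scatter. Also open, from the compounds shown here alone, is what the chlorine on the core contributes, since compound 2 differs from compound 1 in more than one place and its number cannot be assigned to any one change.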